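The compounds below may be only part of what the source reports. "The series", "measured", "known", "first", "only" and "open" are said of these compounds alone.

Working notes on the series. In a functional assay on HepG2 cells (Homo sapiens) for cytotoxicity, read by MTT assay, with a stated time of 48 h (on this read-out lower numbers stand for stronger inhibition and higher numbers for weaker inhibition), compound 1 `CNCC(=O)N1N=C(c2cc3ccccc3oc2=O)CC1c1ccccc1` gives 24000 nM. Compound 2 `CC(C)(C)OC(=O)N1CCN(CC(=O)N2N=C(c3cc4ccccc4oc3=O)CC2c2ccccc2)CC1` gives 28400 nM in this assay. On the numbers shown compound 1 stands at the lower end of the two, with compound 2 within the scatter of it, so no difference between the two is claimed. Among the measured compounds shown here, no pair of measured compounds differing in a single place is available, so no measured step guides the next change.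

Compound 3 `NC(=O)C1CCN(CC(=O)N2N=C(c3cc4ccccc4oc3=O)CC2c2ccccc2)CC1` is not yet measured. Relative to compound 1 the change is 4-carbamoylpiperidin-1-yl in place of methylamino on a saturated chain carbon bound to a carbonyl carbon. The values of compound 1 and compound 2 show that a small group and a considerably larger ring-bearing group return numbers within the scatter of each other, so the step from compound 1 to compound 3 is expected to be none beyond the scatter in this assay, namely a 1.0-fold higher number from compound 1 to compound 3 (0.02 log units; within the scatter). Compound 3 is accordingly estimated at 25000 nM in this assay, with a range from 12000 nM to 52000 nM.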

Compound 3, half-maximal inhibitory concentration: 19300 nM
Estimate against measurement, compound 3: 1.3-fold (0.11 log units) above; measured number inside the range.
By their numbers in this assay, from the lowest: compounds 3, 1 and 2 (each within the scatter of the next).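

Among the compounds shown here, the core of compound 1 carries 4-carbamoylpiperidin-1-yl in place of methylamino on a saturated chain carbon bound to a carbonyl carbon, and this single-place exchange gives a 1.2-fold lower number from compound 1 to compound 3 (0.09 log units; within the scatter) in this assay as the first measured step. At this position, therefore, a ring-bearing group with a carbamoyl substituent and a small open-chain amino group are not separated in this read-out, despite the difference in size printed for the two groups. The step gives a measured reference for further exchanges here, but no direction in which to take them, and no measurement on hand offers an explanation for this outcome.

As far as these compounds go, whether any group at this saturated chain carbon can move the number beyond the scatter remains open, for instance a carboxylic acid in place of the carbamoyl group or a morpholine ring in place of the piperidine ring. The compounds shown also leave open whether a longer chain between the carbonyl carbon and the amine nitrogen would give a different result in this assay from that of compound 3.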